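Ester to Hydroxyanilide on the Thioether Chain

This account rests on a few compounds, and the source may have more. Where it says the series, first, only, none or still open, it means among the compounds named here.

Measured so far:
Compound 1, `Cn1c(Cc2nn(C)c(=O)c3ccccc23)nnc1SCCCCCCCC(=O)Nc1ccc(F)cc1F`: 2300 nM
Compound 2, `CCCCCCCCCCSc1nnc(Cc2nn(C)c(=O)c3ccccc23)n1C`: 7600 nM
Compound 3, `Cn1c(Cc2nn(C)c(=O)c3ccccc23)nnc1SCCCCCCCC(=O)Oc1ccc(Cl)cc1Cl`: 800 nM

All three were tested in an assay on isolated protein (Mus musculus) for inhibition of IL15-IL15 receptor (Homo sapiens), read by resazurin assay, with stated times of 30 min and 2.5 days; a higher number here means a weaker inhibitor, a lower number a stronger inhibitor. Among them compound 3 holds the lowest number: compound 1 sits a 2.9-fold lower number from compound 1 to compound 3 (0.46 log units; beyond the scatter) away in the other direction, and compound 2, the plain alkyl chain, is furthest, with a 9.5-fold lower number from compound 2 to compound 3 (0.98 log units; beyond the scatter). The remaining step, a 3.3-fold higher number from compound 1 to compound 2 (0.52 log units; beyond the scatter), shows that removing the terminal aryl amide altogether costs potency.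

Compound 4, `Cn1c(Cc2nn(C)c(=O)c3ccccc23)nnc1SCCCCCCCC(=O)Nc1ccccc1O`, has not yet been measured. It differs from compound 3 in one place: (2-hydroxyphenyl)amino in place of 2,4-dichlorophenoxy on a carbonyl carbon. Within the data shown here, the change returns the chain end from an ester to an anilide, so the step that bears on it most directly is the one from compound 1 to compound 3, where the amide-to-ester swap read a 2.9-fold lower number from compound 1 to compound 3 (0.46 log units; beyond the scatter). Reversing that swap, with a 2-hydroxyphenyl rather than a 2,4-difluorophenyl ring on the nitrogen, is therefore expected to move the number back up by a modest amount, roughly toward where compound 1 stands. The estimated step for compound 4 is a 2.5-fold higher number from compound 3 to compound 4 (0.40 log units; beyond the scatter). Compound 4 is thus expected to give about 2000 nM in this assay, within a range of 700 nM to 6000 nM.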

Compound 4, half-maximal inhibitory concentration: 27000 nM
The estimate for compound 4 lay 14-fold (1.13 log units) below the measured number, outside the stated range (above it).
By their numbers in this assay, from the lowest: compound 3; then compound 1; then compound 2; then compound 4.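

Changing only the ring on the amide-type nitrogen, with 2-hydroxyphenyl in place of 2,4-difluorophenyl, gives a 12-fold higher number from compound 1 to compound 4 (1.07 log units; beyond the scatter) in this assay, so this ring weighs more heavily here than the earlier amide and ester comparison alone could show. The full change from the ester gives a 34-fold higher number from compound 3 to compound 4 (1.53 log units; beyond the scatter) and therefore cannot be read as a return from ester to anilide alone. The (2-hydroxyphenyl)carbamoyl end also falls behind the plain alkyl chain, with a 3.6-fold higher number from compound 2 to compound 4 (0.55 log units; beyond the scatter), so compound 4 goes against the order seen with compound 1 and compound 3, where the aryl-bearing chain ends gave lower numbers than the alkyl chain of compound 2, and nothing available explains this reversal.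

As far as these compounds go, it remains open whether the loss follows the added hydroxyl or the missing fluorines, which a plain phenyl or a methoxyphenyl on the same nitrogen would help to separate. Also open, from the compounds shown here alone, is how much of the lead held by the ester belongs to its linkage and how much to its chlorines, which a dichlorophenyl anilide would test.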